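Methyl for Chloro on a Compound at the Assay Limit

The source may report more compounds than this note shows. Statements on the series, on what has been measured and on what is new or still open speak of the compounds shown alone.

Compound 1, `O=C(Nc1cc(Sc2ncn[nH]2)c(O)c2ccccc12)c1cccc(Cl)c1`: > 100000 nM
Compound 2, `O=C(Nc1cc(Sc2ncnc3nc[nH]c23)c(O)c2ccccc12)c1ccc([N+](=O)[O-])cc1`: > 100000 nM
Compound 3, `Cn1nnnc1Sc1cc(NC(=O)c2ccc(Cl)cc2)c2ccccc2c1O`: > 100000 nM

All three were measured in a functional assay on MDA-MB-231 cells (Homo sapiens) for antiproliferative activity, read by MTT assay, with a stated time of 48 h; a higher number here means a weaker inhibitor, a lower number a stronger inhibitor. The value of compound 1 is a limit of the assay, not a number. The same holds for compound 2, whose value is also a limit. Compound 3 likewise returns only a limit. Within the data shown here, compound 1 thus stands at the limit of > 100000 nM in this assay, at which 3 of the 3 values shown sit, and nothing among the measured compounds separates it from the other two.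

Compound 4, `Cc1cccc(C(=O)Nc2cc(Sc3ncn[nH]3)c(O)c3ccccc23)c1`, has not yet been measured in this assay. It differs from compound 1 by methyl in place of chloro on an aromatic carbon. Among the measured compounds shown here, no measured pair reports a step for this change, so the expectation rests on the position of compound 1 alone. With compound 1 already at the limit and no step in either direction on record, the expected step of a number no higher from compound 1 to compound 4 (the limit leaves the size open) is none beyond the scatter, and a limit is the most likely outcome. Compound 4 is therefore expected at 100000 nM, with a range from 30000 nM to 300000 nM.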

Compound 4, half-maximal inhibitory concentration: > 100000 nM
Compound 4 was reported as a limit; the forecaster's own chance of this, stated with the estimate: 80%; the middle value lies on the limit itself.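

Among these compounds, compound 1 and compound 4 each return only a limit in this assay, and no step between them can be read. The compounds shown leave open how methyl and chloro compare here, and what value any of them would give within the measurable range: the limit of > 100000 nM in this assay, at which 4 of the 4 values shown sit.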